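Chain lengthening on the shared core: compound 4

The source may hold more compounds than are shown below. What is called first, only, known or untested is meant among the compounds shown, and "the series" means these compounds.

Compound 3 `CCCc1cn([C@H]2C[C@H](O)[C@@H](CO)O2)c(=O)[nH]c1=O` in a functional assay on Raji cells (Homo sapiens) (on this read-out higher numbers stand for weaker inhibition and lower numbers for stronger inhibition), gives only a limit, > 500 ug/mL. Compound 2 `CCCCc1cn([C@H]2C[C@H](O)[C@@H](CO)O2)c(=O)[nH]c1=O` likewise gives only a limit in this assay, > 500 ug/mL. Compound 1 `CCCCCc1cn([C@H]2C[C@H](O)[C@@H](CO)O2)c(=O)[nH]c1=O` gives a readable number in this assay, 334 ug/mL. Compound 3 thus stands at the limit of > 500 ug/mL in this assay, at which 2 of the 3 values shown sit, the same point as compound 2, with nothing readable beyond it. Compound 4 `CCCCCCCCc1cn([C@H]2C[C@H](O)[C@@H](CO)O2)c(=O)[nH]c1=O` differs from compound 3 by pentyl in place of hydrogen on a saturated chain carbon, three bonds along the chain from an aromatic carbon. Within the data shown here, the steps that bear on it run in the opposite sense: an at least 1.4-fold higher number from compound 1 to compound 2 (0.17 log units; that floor lies within the scatter), and an at least 1.4-fold higher number from compound 1 to compound 3 (0.17 log units; that floor lies within the scatter), while a step that the two limits leave unreadable from compound 2 to compound 3. A longer chain is therefore expected to lower the number, and the step from compound 3 to compound 4 is estimated as an at least 3.3-fold lower number from compound 3 to compound 4 (0.52 log units; beyond the scatter). For compound 4 the expected value in this assay is 150 ug/mL, within 40 ug/mL to 500 ug/mL.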

Compound 4, concentration for 50% inhibition: 52 ug/mL
Compound 4: the middle estimate sits 2.9-fold (0.46 log units) above what was measured, and the stated range covers the measured number.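

Lengthening the chain at this position gives the first step in this assay that is readable at both ends and lies beyond the scatter (a 6.4-fold lower number from compound 1 to compound 4 (0.81 log units; beyond the scatter)). The steps from the two shorter chains also lie beyond the scatter (an at least 9.6-fold lower number from compound 3 to compound 4 (0.98 log units; beyond the scatter)) (an at least 9.6-fold lower number from compound 2 to compound 4 (0.98 log units; beyond the scatter)), but both are only floors: the limit of > 500 ug/mL in this assay, at which 2 of the 4 values shown sit.

Among these compounds, whether a longer chain than the one in compound 4 lowers the number further remains open. Also open, on these data alone, is whether a chain ending in an amine or a carboxylic acid would keep this gain.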